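The source may report more compounds than this note shows. Statements on the series, on what has been measured and on what is new or still open speak of the compounds shown alone.

Compound 3 `CC(C)Oc1cncc(C2=CC3CNCC(C2)C3)c1` gives the lowest number of the three measured in an in vitro assay on SH-EP1 cells for displacement of a labelled ligand from Neuronal acetylcholine receptor; alpha4/beta2 (Homo sapiens) (a lower number here means a stronger inhibitor, a higher number a weaker inhibitor), and compound 3 stands at 0.26 nM. Compound 1 `COc1cncc(C2=CC3CC(C2)CN(C)C3)c1` is the nearest of the others: in this assay compound 1 gives 0.6 nM. Compound 2 `CN1CC2C=C(c3cncc(Cl)c3)CC(C2)C1` lies furthest off, and in this assay compound 2 gives 9.6 nM. Within the data shown here, the only single-place step among the measured compounds is a 16-fold higher number from compound 1 to compound 2 (1.20 log units; beyond the scatter), a change on the aromatic ring that has no bearing on a change at the ring amine. Compound 4 `CC(C)Oc1cncc(C2=CC3CC(C2)CN(C)C3)c1` differs from compound 3 by methyl in place of hydrogen on an amine nitrogen in a ring. Compound 1 carries the same methyl on its ring amine, but it also differs from compound 3 at the aromatic ether, so the two values of compound 1 and compound 3 cannot be split between the two changes. Among the measured compounds shown here, with no measured step to lean on, a change beyond the scatter is not expected. The estimated step is a 1.5-fold higher number from compound 3 to compound 4 (0.19 log units; within the scatter). Compound 4 is expected at 0.4 nM in this assay, with a range from 0.15 nM to 1.2 nM.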

Compound 4, inhibition constant: 2.2 nM
The estimate for compound 4 lay 5.5-fold (0.74 log units) below the measured number; measured number outside the range, above it.
By their numbers in this assay, from the lowest: compound 3; then compound 1; then compound 4; then compound 2.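

In this assay, among these compounds, methyl in place of hydrogen on the amine nitrogen in a ring has a real cost with the isopropoxy group held fixed (an 8.5-fold higher number from compound 3 to compound 4 (0.93 log units; beyond the scatter)), the first direct reading at this position. With the methylated ring amine held fixed, the aromatic substituent can now be ranked: isopropyl in place of methyl on the oxygen costs affinity (a 3.7-fold higher number from compound 1 to compound 4 (0.56 log units; beyond the scatter)), while isopropoxy in place of chloro gains it (a 4.4-fold lower number from compound 2 to compound 4 (0.64 log units; beyond the scatter)). No measurement available here accounts for these steps.

Going by these compounds, the hydrogen-bearing ring amine appears only with isopropoxy, so whether methyl carries the same cost with methoxy or chloro on the aromatic ring remains open. Also open, on these data alone, is how an ethyl group on the ring amine, or an ethoxy group on the aromatic ring, would fall.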